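Swapping the dihydroxyphenyl of compound 1 for chlorophenyl

A few compounds are considered here, and "the series" means these few. Any claim that something is new, unique, unknown or untested is made for them only; others in the source may bear on it.

Three compounds from one series were tested in an assay on cells for displacement of a labelled ligand from adenosine receptor A2b (Homo sapiens), read by scintillation counting and radioligand binding, with a stated time of 30 min, tested at 10 uM; a lower number here means less inhibition, a higher number more inhibition at the concentration tested (going by the name of the read-out). Compound 1 `Cn1cnc2c(N3CCCCC3)nc(-c3cccc(O)c3O)nc21` gives 26% in this assay, the highest of the three numbers. Compound 2 `Clc1ccc(-c2nc(N3CCCCC3)c3nc[nH]c3n2)cc1` gives 1.4% in this assay, and compound 3 `CN1CCN(c2nc(-c3ccc(Cl)cc3)nc3[nH]cnc23)CC1` gives 6.2% in this assay. Among the measured compounds shown here, the only step between two compounds that differ in one place is a number 4.8 percentage points higher from compound 2 to compound 3 (within the scatter), a change of 4-methylpiperazin-1-yl in place of piperidin-1-yl on an aromatic carbon. Compound 1 stands well apart from both: its value lies beyond the scatter above compound 3 and further still above compound 2.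

Compound 4 `Cn1cnc2c(N3CCCCC3)nc(-c3ccccc3Cl)nc21` has not yet been measured in this assay. Compared with compound 1 it carries 2-chlorophenyl in place of 2,3-dihydroxyphenyl on an aromatic carbon, on the aromatic carbon of the shared core that sits between two ring nitrogen atoms. For the measured compounds named here, no measured step covers this change; the step from compound 2 to compound 3 concerns a different position. The two compounds that carry a chlorophenyl group, compound 2 and compound 3, both give low numbers, so a downward step is expected. Compound 4 is estimated at 9%, within 0% to 24%, which is expected to be a step of a number 17 percentage points lower from compound 1 to compound 4 (beyond the scatter).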

Compound 4, a percentage reported as inhibition, at one concentration (the size of the read-out at that concentration, not a potency): 32.7%
The estimate for compound 4 lay 23.7 percentage points below the measured number, outside the stated range (above it).
By their numbers in this assay, from the lowest: compounds 2 and 3 (each within the scatter of the next); then compounds 1 and 4 (each within the scatter of the next).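

The change to 2-chlorophenyl in place of 2,3-dihydroxyphenyl on the aromatic carbon between two ring nitrogen atoms, read in this assay, amounts to a number 6.7 percentage points higher from compound 1 to compound 4 (within the scatter) and so does not separate the two groups at this position. The hydrogen-bond donors and acceptors counted on 2,3-dihydroxyphenyl are absent from 2-chlorophenyl, yet compound 1 and compound 4 remain within the scatter of each other, so in this pair the read-out does not fall when those donors and acceptors go. Carrying a chlorophenyl group therefore does not by itself go with a low number, although compound 2 and compound 3 differ from compound 4 in more than one place and cannot be compared with it directly.

Going by these compounds, whether an unsubstituted phenyl group at this position, or a phenyl ring bearing an amine or a carboxylic acid, would give a number in the same range remains open, as does whether a larger change at this position would move the number beyond the scatter. Nothing shown here gives a reason for the similar numbers of this pair.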